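Working notes: cytotoxicity of compounds 1 to 4

The compounds below may be only part of what the source reports. "The series", "measured", "known", "first", "only" and "open" are said of these compounds alone.

Measured so far:
compound 1 `CC1CCCN(C(=S)SC(=S)N(C)C)C1` — 2900000 nM
compound 2 `CN(C)C(=S)SC(=S)N1CCN(c2cccc(Cl)c2)CC1` — a limit, > 5000000 nM
compound 3 `CN(C)C(=S)SC(=S)N1CCN(C(=O)c2ccco2)CC1` — 2380000 nM

In an ADME assay on HeLa cells (Homo sapiens) for cytotoxicity, read by MTT assay, with a stated time of 24 h (on this read-out higher numbers stand for weaker inhibition and lower numbers for stronger inhibition), compound 1 gives 2900000 nM. Compound 2 gives > 5000000 nM, which is a limit of the assay and not a number (the limit of > 5000000 nM in this assay, at which 1 of the 3 values shown sits). Compound 3 gives 2380000 nM, the lowest of the two numbers shown; compound 1 sits within the scatter of it, so no order between those two is claimed. Among the measured compounds shown here, the single step between neighbours that differ in one place is an at least 2.1-fold lower number from compound 2 to compound 3 (0.32 log units; beyond the scatter).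

Compound 4 `CCCCNC(=S)N1CCN(C(=S)SC(=S)N(C)C)CC1` has not been measured. It differs from compound 3 in one place: a group of 7 heavy atoms (5 carbon, 1 nitrogen, 1 sulfur; no ring) in place of a group of 7 heavy atoms (5 carbon, 2 oxygen; one five-membered aromatic ring with 1 hetero atom), on an amine nitrogen in a ring. For the measured compounds named here, no measured step makes this kind of change; the one measured step at this position, an at least 2.1-fold lower number from compound 2 to compound 3 (0.32 log units; beyond the scatter), replaces an aromatic ring group with a carbonyl-bearing group and is modest in size, so for compound 4 the change is expected to be small or none beyond the scatter. Compound 4 is therefore expected to give about 2500000 nM, within 1000000 nM to 6000000 nM, the expected step being a 1.1-fold higher number from compound 3 to compound 4 (0.02 log units; within the scatter).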

Compound 4, half-maximal inhibitory concentration: 2840000 nM
Estimate against measurement, compound 4: 1.1-fold (0.06 log units) below, and the stated range covers the measured number.
By their numbers in this assay, from the lowest: compounds 3, 4 and 1 (each within the scatter of the next). At a limit, above all of these: compound 2.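

In this assay, the step of a 1.2-fold higher number from compound 3 to compound 4 (0.08 log units; within the scatter) shows that, on this amine nitrogen in a ring, a group with no ring and one hydrogen-bond donor can replace (furan-2-yl)carbonyl without a change beyond the scatter, so the five-membered aromatic ring is not needed to hold the number at this level. Compound 2 carries a limit and not a number: the limit of > 5000000 nM in this assay, at which 1 of the 4 values shown sits. The step of an at least 1.7-fold lower number from compound 2 to compound 4 (0.24 log units; that floor lies within the scatter) therefore does not separate the new group from 3-chlorophenyl.

As far as these compounds go, whether a free amine, a carboxylic acid or a longer alkyl chain at this position would move the number beyond the scatter remains open. Also open is whether the hydrogen-bond donor of the entering group matters at all: no pair shown changes that feature alone.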